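The compounds below may be only part of what the source reports. "The series", "measured", "known", "first", "only" and "open" are said of these compounds alone.

Values in a physicochemical assay for solubility, using the shake flask method, in simulated intestinal fluid, measured as kinetic solubility, with a stated time of 20 h, at pH 6.5; on this read-out higher numbers stand for higher solubility and lower numbers for lower solubility:
- compound 1 `N#Cc1ccc(Nc2cc3[nH]c(-c4cccc(C(F)(F)F)c4)nc3cn2)nc1`: >= 50000 nM (a limit)
- compound 2 `CN1CCN(c2ccc(Nc3cc4[nH]c(-c5cccc(C(F)(F)F)c5)nc4cn3)nc2)CC1`: < 5000 nM (a limit)
- compound 3 `FC(F)(F)c1ccc(Nc2cc3[nH]c(C4CCOC4)nc3cn2)nc1`: 180000 nM

Among the measured compounds shown here, compound 3 holds the only actual number of the three, as the other two values are limits. Compound 4 `FC(F)(F)c1ccc(Nc2cc3[nH]c([C@H]4CC[C@H](C(F)(F)F)CC4)nc3cn2)nc1` carries 4-(trifluoromethyl)cyclohexyl in place of oxolan-3-yl on an aromatic carbon. For the measured compounds named here, no measured step changes this place. Going by the values given here, the one measured step, an at least 10-fold lower number from compound 1 to compound 2 (1.00 log units; beyond the scatter), lies elsewhere on the molecule and bears only indirectly, showing that a single change can move this assay well beyond the scatter, towards a lower number. The expected step is a 36-fold lower number from compound 3 to compound 4 (1.56 log units; beyond the scatter), in the same direction and beyond the scatter. For compound 4 the estimate is 5000 nM, with an expected range of 1500 nM to 30000 nM.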

Compound 4, solubility: 104000 nM
For compound 4 the middle estimate is 21-fold (1.32 log units) below the measured one; the whole stated range lies below it.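

In this assay, the position on an aromatic carbon between two ring nitrogen atoms now has a measured step: a 1.7-fold lower number from compound 3 to compound 4 (0.24 log units; within the scatter). The exchange removes the ring oxygen and its hydrogen-bond acceptor and adds trifluoromethyl and 2 defined stereocentres, yet compound 3 and compound 4 stay within the scatter of each other. Nothing measured here accounts for this result.

Still open, going by these compounds, is whether an amine or a carboxylic acid at this position would give a step beyond the scatter. Also open, on these data alone, is whether the same exchange reads alike with the 4-methylpiperazin-1-yl group of compound 2 present.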